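The compounds below may be only part of what the source reports. "The series", "measured", "known", "first", "only" and "open" are said of these compounds alone.

Compound 1 `CC(C)[C@H](NC(=O)COc1cccc2ccccc12)C(=O)N[C@@H](CC(=O)O)C(=O)COc1cccc(C(F)(F)F)c1` gives > 100000 nM in a functional assay on Jurkat cells (Homo sapiens) (a higher number here means a weaker inhibitor, a lower number a stronger inhibitor), which is a limit of the assay and not a number. Compound 2 `CC(C)[C@H](NC(=O)COc1cccc2ccccc12)C(=O)N[C@@H](CC(=O)O)C(=O)COc1ccccc1[N+](=O)[O-]` likewise reaches only a limit, at > 100000 nM in this assay. Compound 3 `CC(C)[C@H](NC(=O)COc1cccc2ccccc12)C(=O)N[C@@H](CC(=O)O)C(=O)COc1ccc(F)cc1F` gives 33200 nM in this assay. The change to compound 4 `CC(C)[C@H](NC(=O)COc1cccc2ccccc12)C(=O)N[C@@H](CC(=O)O)C(=O)COc1ccc(F)c(F)c1` is 3,4-difluorophenyl in place of 3-(trifluoromethyl)phenyl on an oxygen on a saturated carbon. The closest measured steps are an at least 3.0-fold lower number from compound 1 to compound 3 (0.47 log units; beyond the scatter) and an at least 3.0-fold lower number from compound 2 to compound 3 (0.47 log units; beyond the scatter), both bringing in a 2,4-difluorophenyl; the step that the two limits leave unreadable from compound 1 to compound 2 is unreadable because of the limit of > 100000 nM in this assay, at which 2 of the 3 values shown sit. A 3,4-difluorophenyl is taken to behave much as the 2,4-difluorophenyl of compound 3, so the expected step is an at least 2.5-fold lower number from compound 1 to compound 4 (0.39 log units; beyond the scatter), with a fair chance that only a limit is returned. Compound 4 is estimated at 40000 nM, with a range from 12000 nM to 130000 nM.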

Compound 4, half-maximal inhibitory concentration: > 100000 nM
Compound 4: no number, only a limit; the forecaster's own chance of this, stated with the estimate: 35%; at least 2.5-fold (0.39 log units) between middle value and limit.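

Replacing the 2,4-difluorophenyl with the 3,4-difluorophenyl on this oxygen gives an at least 3.0-fold higher number from compound 3 to compound 4 (0.47 log units; beyond the scatter), so at this position the placing of the two fluorines matters, not only their presence. Of the four groups shown here, only the 2,4-difluorophenyl of compound 3 returns a number in this assay. The steps from compound 1 and from compound 2 to compound 4 cannot be read: the limit of > 100000 nM in this assay, at which 3 of the 4 values shown sit.

On these data alone, whether a 2-fluorophenyl or a 4-fluorophenyl at this position would also return a number in this assay stays open. Also open, as far as these compounds go, is how far compound 1, compound 2 and compound 4 differ from one another beyond the limit.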